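Swapping the Side Chain on a Piperidine Agonist

The source may hold more compounds than are shown below. What is called first, only, known or untested is meant among the compounds shown, and "the series" means these compounds.

Compound 1 `OCCC(NC1CCN(CCCc2c[nH]c3ccc(-n4cnnc4)cc23)CC1)c1ccccc1` gives the larger of the two responses recorded in a functional assay on CHO cells for activation of 5-hydroxytryptamine receptor 1D (Homo sapiens), read by GTPgammaS binding; a lower number here means a smaller maximal response, a higher number a larger maximal response: compound 1 reaches 100%. Compound 2 `c1ccc(C2CCCCN2C2CCN(CCCc3c[nH]c4ccc(-n5cnnc5)cc34)CC2)cc1` reaches 65% in this assay, a clearly smaller maximal response than compound 1, with the gap beyond the usual scatter. Compound 3 `c1ccc2c(c1)CCC2NCC1CCN(CCCc2c[nH]c3ccc(-n4cnnc4)cc23)CC1` has not yet been tested. It differs from compound 1 at a single place: ((2,3-dihydro-1H-inden-1-yl)amino)methyl in place of (3-hydroxy-1-phenylpropyl)amino on a saturated ring carbon. The change sits on a saturated ring carbon of the six-membered non-aromatic ring with one nitrogen, three ring bonds from that nitrogen. Going by the values given here, no measured pair of compounds shows this exact change, so any expectation rests only on the two numbers at hand. Compound 3 is expected to give 80%, with a likely range from 55% to 100%. This corresponds to an expected moderate downward step a number 20 percentage points lower from compound 1 to compound 3 (beyond the scatter), somewhat smaller than the gap between compound 1 and compound 2.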

Compound 3, largest response reached (reported as efficacy), in percent of the reference or control that the assay uses: 78%
For compound 3 the middle estimate is 2 percentage points above the measured one; the range from low to high includes it.
By their numbers in this assay, from the lowest: compound 2; then compound 3; then compound 1.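

In this assay, the saturated ring carbon three ring bonds from the ring nitrogen accepts a complete change of side chain without losing the response: ((2,3-dihydro-1H-inden-1-yl)amino)methyl in place of (3-hydroxy-1-phenylpropyl)amino gives a modest step, a number 22 percentage points lower from compound 1 to compound 3 (beyond the scatter). Both groups hold 11 heavy atoms, but the entering group has a five-membered non-aromatic ring and no oxygen, so several features change at once and this single step cannot assign the loss to any one of them. Nothing available here explains the drop.

Whether the oxygen alone accounts for the step remains open, since no compound shown separates it from the added ring. It is also unknown how a hydroxyl on the 2,3-dihydro-1H-inden-1-yl ring, or a plain benzylamino group at this carbon, would behave.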